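The source may report more compounds than this note shows. Statements on the series, on what has been measured and on what is new or still open speak of the compounds shown alone.

Measured in an ADME assay on the whole organism (Macaca fascicularis) for metabolic stability, read by LC-MS, using cassette dosing, at a dose of 1 mg/kg by the oral route; on this read-out higher numbers stand for a longer-lived compound and lower numbers for a shorter-lived compound:
- compound 1 `CCCCN(c1nc2c(C(=O)N(C)C)cccc2o1)[C@H](C)c1ccc(-c2ccccc2-c2nnn[nH]2)cc1`: 3.2 h
- compound 2 `CCCCN(c1nc2c(-c3nccn3C)cccc2o1)[C@H](C)c1ccc(-c2ccccc2-c2nnn[nH]2)cc1`: 3.9 h
- compound 3 `CCCCN(c1nc2c(C(=O)NS(C)(=O)=O)cccc2o1)[C@H](C)c1ccc(-c2ccccc2-c2nnn[nH]2)cc1`: 2.7 h

Compound 3 shows the smallest of the three numbers, but its gap to compound 1 and its gap to compound 2 are both within the scatter, so no ordering among the three can be claimed. The three measured steps are all exchanges of the group on the same aromatic carbon of the shared core: a 1.2-fold higher number from compound 1 to compound 2 (0.09 log units; within the scatter), a 1.2-fold lower number from compound 1 to compound 3 (0.07 log units; within the scatter) and a 1.4-fold lower number from compound 2 to compound 3 (0.16 log units; within the scatter). None of them moved the half-life in this assay beyond the scatter.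

Compound 4 `CCCCN(c1nc2ccccc2o1)[C@H](C)c1ccc(-c2ccccc2-c2nnn[nH]2)cc1` differs from compound 3 in one place: hydrogen in place of (methylsulfonyl)carbamoyl on an aromatic carbon. Going by the values given here, no measured step removes the group at that position altogether; the nearest guides are the two exchanges ending at compound 3, which were both within the scatter. With three different groups at that carbon giving indistinguishable half-lives, the step to compound 4 is expected to be small as well, with no clear direction: a 1.1-fold higher number from compound 3 to compound 4 (0.05 log units; within the scatter). For compound 4 in this assay the half-life is therefore estimated at 3 h, within a range of 1.5 h to 6 h, the width reflecting that a bare hydrogen at this position has not been tested in the series.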

Compound 4, half-life: 3.2 h
Beside the measured number, compound 4's estimate is 1.1-fold (0.03 log units) below it, and the stated range covers the measured number.
By their numbers in this assay, from the lowest: compounds 3, 1, 4 and 2 (each within the scatter of the next).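

In this assay the group on this aromatic carbon can now be read against hydrogen, not only against another group: with (methylsulfonyl)carbamoyl leaving, the result is a 1.2-fold higher number from compound 3 to compound 4 (0.07 log units; within the scatter); with 1-methyl-1H-imidazol-2-yl leaving, it is a 1.2-fold lower number from compound 2 to compound 4 (0.09 log units; within the scatter); and with dimethylcarbamoyl leaving, it is no change at the digits printed from compound 1 to compound 4 (within the scatter). Going by these compounds alone, the earlier compounds showed only that three groups could replace one another at this carbon without a step beyond the scatter, whereas these steps show that the half-life does not depend on having any of the three there, even though the largest of them takes 7 heavy atoms with it. No information is available on why the position is this insensitive.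

From the compounds shown here alone, whether a carboxylic acid or a primary amine on this aromatic carbon would also stay within the scatter of hydrogen remains open. Also open, going by these compounds, is whether the half-life responds to a change elsewhere on the shared core, such as a longer chain in place of the butyl chain on the nitrogen.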